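Hydroxamic acid series: pyridinyl for benzothiophenyl on the triazole

The compounds below may be only part of what the source reports. "The series", "measured", "known", "first", "only" and "open" are said of these compounds alone.

Compound 1 `O=C(NO)c1ccc(NCc2nc(-c3cc4ccccc4s3)nn2-c2ccccc2)cc1` is, on the two numbers in hand, the higher one: in an assay on Sf9 cells for inhibition of protein deacetylase HDAC6 (Homo sapiens), read by fluorescence, with a stated time of 40 min, tested at 100 nM (a higher number here means more inhibition at the concentration tested (going by the name of the read-out), a lower number less inhibition), compound 1 gives 65.5%, while compound 2 `NC(=O)c1ccc(NCc2nc(-c3ccccc3)nn2-c2ccccc2)cc1` gives -4.4% in this assay, a gap that lies beyond the scatter. Within the data shown here, no pair of measured compounds differing in a single place exists, so no measured step can be quoted.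

Compound 3 `O=C(NO)c1ccc(NCc2nc(-c3ccccn3)nn2-c2ccccc2)cc1` has not been measured. Relative to compound 1 the change is pyridin-2-yl in place of 1-benzothiophen-2-yl on an aromatic carbon. The hydroxamic acid and the remainder of the shared core of compound 1 are kept; only the group on the aromatic carbon of the five-membered aromatic ring with 3 nitrogen is exchanged.

With the part common to compound 1 retained, compound 3 is expected to keep inhibition in this assay, though the step of a number 15.5 percentage points lower from compound 1 to compound 3 (beyond the scatter) is estimated to run downward, because compound 1 gives 65.5% and a smaller group enters. The expected value for compound 3 in this assay is 50%, with a range from 25% to 75%.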

Compound 3, a percentage reported as inhibition, at one concentration (the size of the read-out at that concentration, not a potency): 58.6%
Compound 3: the middle estimate sits 8.6 percentage points below what was measured; low and high end bracket the measured number.
By their numbers in this assay, from the lowest: compound 2; then compounds 3 and 1 (each within the scatter of the next).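

In this assay the exchange of 1-benzothiophen-2-yl for pyridin-2-yl on an aromatic carbon of the five-membered aromatic ring with 3 nitrogen gives a number 6.9 percentage points lower from compound 1 to compound 3 (within the scatter), the first single-place comparison available in the hydroxamic acid series. Among these compounds, at this position, therefore, a two-ring group of 9 heavy atoms and a one-ring group of 6 heavy atoms with a ring nitrogen cannot be told apart at the single concentration tested, and the read-out gives no potency for either compound. Nothing measured on these compounds accounts for this result.

Open, as far as these compounds go, is whether this position accepts groups of another kind, such as a morpholine ring, a carboxylic acid or a longer alkyl chain, as it accepts these two aromatic groups. Also open is how far the read-out depends on the hydroxamic acid and on the phenyl group on the ring nitrogen, since no pair of compounds shown differs in only one of these places.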